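Replacing the Acid Side Chain by Fluorine: Cytotoxicity Outlook

The source may hold more compounds than are shown below. What is called first, only, known or untested is meant among the compounds shown, and "the series" means these compounds.

The study measures cytotoxicity in an ADME assay on MDBK cells (Bos taurus) for cytotoxicity, read by MTT assay, with a stated time of 96 h; on this read-out higher numbers stand for lower toxicity in this test and lower numbers for higher toxicity in this test. Compound 1 `O=C(O)CCC(=O)Nc1ccc(-c2nc3cc(C(F)(F)F)ccc3[nH]2)cc1` carries a ((2-carboxyethyl)carbonyl)amino group on its outer aromatic ring, para to the large core. In this assay compound 1 reaches only the limit of the assay, > 100000 nM, and no number. Compound 2 `CC(=O)Nc1ccc(-c2nc3ccccc3[nH]2)cc1` likewise sits at the limit, giving > 100000 nM in this assay. Within the data shown here, compound 3 `COc1ccc(-c2nc3cc(Cl)c(Cl)cc3[nH]2)c([N+](=O)[O-])c1` is the single compound with a number: in this assay compound 3 gives 28000 nM. Compound 1 thus stands at the limit (the limit of > 100000 nM in this assay, at which 2 of the 3 values shown sit), so its exact position among the three is not known.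

Compound 4 `Fc1ccc(-c2nc3cc(C(F)(F)F)ccc3[nH]2)cc1` differs from compound 1 by fluoro in place of ((2-carboxyethyl)carbonyl)amino on an aromatic carbon. Among the measured compounds shown here, no pair of measured compounds that differ in one place is present, so the size of this step has no direct precedent. Compound 3, which also lacks an acid chain, gives 28000 nM in this assay. This suggests that compound 4, too, may give a number rather than stay at the edge of what the assay can report. Compound 4 is therefore expected to show a step of an at least 2.2-fold lower number from compound 1 to compound 4 (0.34 log units; beyond the scatter) from compound 1, that is, toward higher toxicity. In this assay compound 4 is estimated at 45000 nM, within a range from 12000 nM to 100000 nM, with a fair chance that only a limit is reported.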

Compound 4, half-maximal cytotoxic concentration: 19000 nM
Compound 4: the middle estimate sits 2.4-fold (0.37 log units) above what was measured; low and high end bracket the measured number.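

In this assay the exchange of the ((2-carboxyethyl)carbonyl)amino group for fluoro, on an aromatic carbon para to a large group, gives an at least 5.2-fold lower number from compound 1 to compound 4 (0.72 log units; beyond the scatter) and moves the compound off the assay limit, toward higher toxicity in this test. Among these compounds, this is the first pair that differs in one place, so it shows what the earlier compounds could not: a change at this position alone, with the rest of compound 1 kept, is enough to produce a step beyond the usual scatter. On these data alone, the step gives only a minimum size and its true size remains unknown, because compound 1 gives only a limit and no number: the limit of > 100000 nM in this assay, at which 2 of the 4 values shown sit.

As far as these compounds go, whether the step comes from losing the chain or from gaining fluoro remains open, since this single exchange does both at once. Also open, from the compounds shown here alone, is how the number would respond to a plain amine, a carboxylic acid set directly on the same aromatic carbon, or a longer chain ending in a carboxylic acid at this position.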